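The source may hold more compounds than are shown below. What is called first, only, known or untested is meant among the compounds shown, and "the series" means these compounds.

Working notes on the series, read in a functional assay on A2780 cells (Homo sapiens) for cytotoxicity, read by MTT assay, with a stated time of 24 h; on this read-out higher numbers stand for weaker inhibition and lower numbers for stronger inhibition. Compound 1 (`CCCCC[C@H](CCC[C@@H]1CC=CC(=O)O1)OC`) gives 14400 nM, compound 2 (`CCCCC[C@@H](C[C@H](O)C[C@@H]1CC=CC(=O)O1)OC`) gives 35400 nM and compound 3 (`CCCCC[C@@H](C[C@@H](O)C[C@@H]1CC=CC(=O)O1)OC`) gives 49400 nM. Compound 3 stands within the scatter of compound 2, while compound 1 stands at a lower number, beyond the scatter.

Next in line is compound 4 (`CCCCC[C@H](C[C@@H](O)C[C@@H]1CC=CC(=O)O1)OC`). Its relation to compound 3 is: the two compounds have the same atoms and bonds and differ only in configuration as drawn: 1 of 3 stereo elements differ; a stereocentre at a saturated chain carbon is drawn S in compound 3 and R in compound 4.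

Among the measured compounds shown here, one measured step bears on this change: a 1.4-fold higher number from compound 2 to compound 3 (0.14 log units; within the scatter). That step is also an inversion from S to R at a saturated chain carbon, but at a different stereocentre. The stereocentre changing now has no measured inversion of its own, so the transfer is loose and the range is kept wide. Compound 1 is not linked to the others by a single-place step and adds nothing here.

In this assay, no step beyond the scatter is therefore expected, and no direction is favoured. The expected change is small: a 1.2-fold lower number from compound 3 to compound 4 (0.09 log units; within the scatter). For compound 4 the estimated value is 40000 nM, with an expected range of 18000 nM to 85000 nM.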

Compound 4, half-maximal inhibitory concentration: 54500 nM
Estimate against measurement, compound 4: 1.4-fold (0.13 log units) below, and the stated range covers the measured number.
By their numbers in this assay, from the lowest: compound 1; then compounds 2, 3 and 4 (each within the scatter of the next).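

In this assay, the stereocentre at this saturated chain carbon now has a measured inversion of its own, and a 1.1-fold higher number from compound 3 to compound 4 (0.04 log units; within the scatter) stays within the scatter, from a clean comparison: the fact that compounds 3 and 4 differ only in the configuration as drawn. Inverting two stereocentres at once gives a 1.5-fold higher number from compound 2 to compound 4 (0.19 log units; within the scatter) and also stays within the scatter, so no configuration as drawn separates compounds 2, 3 and 4 in this assay. Among the compounds shown here, the only step here beyond the scatter is the one with hydroxy in place of hydrogen on a saturated chain carbon bound to two saturated chain carbons, where a 3.8-fold higher number from compound 1 to compound 4 (0.58 log units; beyond the scatter) is a modest change, with compound 1 at the lower number.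

Whether this modest step is specific to hydroxy stays open, since the compounds shown do not say what an amine or a ketone at that carbon would give. Also open, from the compounds shown here alone, is whether the lack of separation by configuration would persist with a longer chain, or with a change to the shared core.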